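Swapping a Furan Ring for a Methoxyphenyl Group

The source may hold more compounds than are shown below. What is called first, only, known or untested is meant among the compounds shown, and "the series" means these compounds.

Measured compounds:
compound 1 `Cc1ccccc1-n1nc(C)c2c1NC(=O)[C@H](C)S[C@@H]2c1ccc(-c2ccoc2)cc1` — 40%
compound 2 `COc1ccccc1-n1nc(C)c2c1NC(=O)[C@H](C)S[C@@H]2c1ccc(Oc2ccccc2)cc1` — 37%

In an assay on isolated protein for agonist activity at Bile acid receptor (Homo sapiens), read by AlphaScreen, with a stated time of 30 min (on this read-out higher numbers stand for larger maximal responses and lower numbers for smaller maximal responses), compound 1 gives 40%, the higher of the two numbers, but compound 2 at 37% lies within the usual scatter, so the two cannot be ranked. Compound 3 `COc1cccc(-c2ccc([C@H]3S[C@@H](C)C(=O)Nc4c3c(C)nn4-c3ccccc3C)cc2)c1` shares the core of compound 1 and differs by one change: 3-methoxyphenyl in place of furan-3-yl on an aromatic carbon. Going by the values given here, no measured pair shows what this change does. Since compound 2 carries a different six-membered aromatic group at the same place and gives 37%, the step of a number 2 percentage points lower from compound 1 to compound 3 (within the scatter) is expected to stay within the scatter. Compound 3 is estimated at 38%, between 25% and 52%.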

Compound 3, largest response reached (reported as efficacy), in percent of the reference or control that the assay uses: 41%
Compound 3: middle estimate off by 3 percentage points, on the low side; the range from low to high includes it.
By their numbers in this assay, from the lowest: compounds 2, 1 and 3 (each within the scatter of the next).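

Going by these compounds alone, replacing furan-3-yl with 3-methoxyphenyl on this aromatic carbon, para to a large group, gives a number 1 percentage points higher from compound 1 to compound 3 (within the scatter) and is the first measured pair at this position. The two compounds cannot be told apart, even though the entering group has 8 heavy atoms and the leaving group 5. Nothing shown explains this result. As far as these compounds go, it remains open whether a carboxylic acid or an amine such as piperidin-4-yl at this place would give a maximal response beyond the scatter. From the compounds shown here alone, what a plain phenyl group would give is also open.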